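From Hydroxy to Methyl: An Expected Loss of Cytotoxicity

The compounds below may be only part of what the source reports. "The series", "measured", "known", "first", "only" and "open" are said of these compounds alone.

Compound 1 `O=C1c2ccccc2OCC1Cc1ccc(F)cc1`: > 200000 nM
Compound 2 `O=C1c2ccccc2OCC1Cc1ccc(O)cc1`: 42800 nM

Going by the values given here, in a functional assay on HeLa cells (Homo sapiens) for cytotoxicity, read by MTT assay, with a stated time of 24 h (on this read-out lower numbers stand for stronger inhibition and higher numbers for weaker inhibition), compound 2 gives 42800 nM, the only actual number so far. Compound 1 stands at > 200000 nM, which is a limit of the assay. Compound 3 `Cc1ccc(CC2COc3ccccc3C2=O)cc1` carries methyl in place of hydroxy on an aromatic carbon, methyl in place of hydroxy on an aromatic carbon. Among the compounds with values here, one measured step bears on this change, and it put hydroxy in place of fluoro. Compound 3 has no hydroxy, so much of an at least 4.6-fold lower number from compound 1 to compound 2 (0.66 log units; beyond the scatter) is expected to be lost, giving a higher number in this assay. The expected change is a 2.3-fold higher number from compound 2 to compound 3 (0.37 log units; beyond the scatter). For compound 3 the estimate is 100000 nM, with an expected range from 35000 nM to 300000 nM.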

Compound 3, half-maximal inhibitory concentration: 48900 nM
Estimate against measurement, compound 3: 2.0-fold (0.31 log units) above; the measured number falls inside the stated range.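

In this assay, hydroxy proves not to be required at this position: methyl in its place gives a 1.1-fold higher number from compound 2 to compound 3 (0.06 log units; within the scatter). Methyl in place of fluoro gives an at least 4.0-fold lower number from compound 1 to compound 3 (0.61 log units; beyond the scatter), which means the gain first seen with hydroxy is also seen with a group that has 0 hydrogen-bond donors. The full size of that step cannot be read, since the value of compound 1 is a limit: the limit of > 200000 nM in this assay, at which 1 of the 3 values shown sits.

Still open, on these data alone, is what an amine or a carboxylic acid would do at this position. A longer chain, such as ethyl, is equally untested among the compounds shown here.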